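From pyrimidin-2-yl to 4-aminophenyl on a sulfur

The source may report more compounds than this note shows. Statements on the series, on what has been measured and on what is new or still open speak of the compounds shown alone.

Values in a functional assay on U2OS cells (Homo sapiens) for antiproliferative activity, read by MTT assay, with a stated time of 72 h; a lower number here means a stronger inhibitor, a higher number a weaker inhibitor:
compound 1 `O=C(CSc1nc2ccccc2[nH]1)Nc1ccc2nc(NC(=O)c3ccc(C(F)(F)F)cc3)sc2c1`: 7110 nM
compound 2 `O=C(CSc1ncccn1)Nc1ccc2nc(NC(=O)c3ccc(C(F)(F)F)cc3)sc2c1`: 28100 nM
compound 3 `Cn1c(CNC(=O)c2cccs2)nnc1SCC(=O)Nc1cccc(Cl)c1`: > 100000 nM
compound 4 `Nc1ccc(SCC(=O)Nc2ccc3nc(NC(=O)c4ccc(C(F)(F)F)cc4)sc3c2)cc1`: not yet measured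

For compound 3 the reported > 100000 nM is a limit of the assay and not a number. For the measured compounds named here, of the two true numbers, the higher belongs to compound 2 at 28100 nM, and its only neighbour is compound 1 at 7110 nM.

Compound 4 keeps the rest of compound 2 and changes only the group on the sulfur: 4-aminophenyl in place of pyrimidin-2-yl on a sulfur. Going by the values given here, one measured step bears on this, the exchange of 1H-benzimidazol-2-yl for pyrimidin-2-yl at that same sulfur, which gave a 4.0-fold higher number from compound 1 to compound 2 (0.60 log units; beyond the scatter). This single step shows that the group on the sulfur can shift the number modestly, and compound 2 sits at the high end of it. A modest move back down is therefore expected, estimated as a 2.3-fold lower number from compound 2 to compound 4 (0.37 log units; beyond the scatter). For compound 4 the expected value in this assay is 12000 nM, with an estimated range of 3500 nM to 40000 nM.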

Compound 4, half-maximal inhibitory concentration: 1220 nM
Compound 4: the middle estimate sits 9.8-fold (0.99 log units) above what was measured; measured number below the stated range.
By their numbers in this assay, from the lowest: compound 4; then compound 1; then compound 2. At a limit, above all of these: compound 3.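

In this assay the group on the sulfur carries far more weight than the earlier pair showed, with 4-aminophenyl in place of pyrimidin-2-yl giving a large step (a 23-fold lower number from compound 2 to compound 4 (1.36 log units; beyond the scatter)). The same group also stands clear of 1H-benzimidazol-2-yl (a 5.8-fold lower number from compound 1 to compound 4 (0.77 log units; beyond the scatter)), so among the three groups on this sulfur with the rest of the molecule unchanged, the one with a six-membered aromatic ring of carbon only gives the lowest number. Nothing measured here accounts for this difference.

The compounds shown leave open whether the drop goes with the amine or with the carbon-only ring, which a plain phenyl or a 4-hydroxyphenyl on the sulfur would help to separate. They also leave open whether an acetylated or methylated amine would keep the low number.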